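The source may hold more compounds than are shown below. What is called first, only, known or untested is meant among the compounds shown, and "the series" means these compounds.

Working notes on the series. In a functional assay on SMMC-7721 cells (Homo sapiens) for cytotoxicity, read by MTT assay, with a stated time of 24 h (a higher number here means a weaker inhibitor, a lower number a stronger inhibitor), compound 1 `O=C1/C(=C/c2ccncc2)CN(S(=O)(=O)c2ccc(C(F)(F)F)cc2)C/C1=C\c1ccccc1F` gives 11100 nM, compound 2 `O=C1/C(=C/c2ccncc2)CN(S(=O)(=O)c2ccc(Cl)cc2)C/C1=C\c1ccccc1F` gives 9600 nM and compound 3 `O=C1/C(=C/c2ccncc2)CN(S(=O)(=O)c2ccc(Br)cc2)C/C1=C\c1ccccc1F` gives 12600 nM. Compound 2 therefore stands within the scatter of both other compounds, and no order can be drawn among the three.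

Compound 4 `O=C1/C(=C/c2ccncc2)CN(S(=O)(=O)c2ccc(Cl)cc2)C/C1=C\c1ccccc1C(F)(F)F` is reached from compound 2 by one change, 2-fluorophenyl to 2-(trifluoromethyl)phenyl: trifluoromethyl in place of fluoro on an aromatic carbon.

For the measured compounds named here, no step at this place has been measured. The three measured steps all lie at a different place in the molecule: a 1.2-fold lower number from compound 1 to compound 2 (0.06 log units; within the scatter), a 1.1-fold higher number from compound 1 to compound 3 (0.06 log units; within the scatter) and a 1.3-fold higher number from compound 2 to compound 3 (0.12 log units; within the scatter). Each stays within the scatter, including the exchange between chloro and trifluoromethyl, so they give only indirect support and point to no direction.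

The estimated step of a 1.0-fold higher number from compound 2 to compound 4 (0.02 log units; within the scatter) is expected to stay within the scatter, with no direction favoured. On these data alone, for compound 4 the expected value in this assay is 10000 nM, with an estimated range from 5000 nM to 20000 nM, kept wide as this place is untested.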

Compound 4, half-maximal inhibitory concentration: 5510 nM
Compound 4: the middle estimate sits 1.8-fold (0.26 log units) above what was measured, within the range that was stated.
By their numbers in this assay, from the lowest: compounds 4, 2, 1 and 3 (each within the scatter of the next, the first and the last beyond it).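

In this assay, for the compounds shown here, the exchange of 2-fluorophenyl for 2-(trifluoromethyl)phenyl gives a 1.7-fold lower number from compound 2 to compound 4 (0.24 log units; within the scatter) and is the first measured step at this place on the shared core. On an aromatic carbon ortho to a large group, trifluoromethyl with its 4 heavy atoms thus stands in for fluoro with its 1 without a step beyond the scatter, though this rests on one pair and the step is wider than the three measured at the other place. Nothing available bears on the cause of this result.

On these data alone, whether this place tolerates an amine, a methoxy group or a carboxylic acid remains open. Also open, as far as these compounds go, is whether the exchange reads alike when bromo or trifluoromethyl replaces chloro at the other place.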